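What a nitro group may do to compound 2

A few compounds are considered here, and "the series" means these few. Any claim that something is new, unique, unknown or untested is made for them only; others in the source may bear on it.

Compound 1 `OC[C@@H](O[C@H]1CCCN(Cc2ncc[nH]2)[C@H]1c1ccccc1)c1cc(Cl)cc(Cl)c1` gives 2 10^-6 cm/s
Compound 2 `O=C(O)c1ccc(CN2CCC[C@H](O[C@H](CO)c3cc(Cl)cc(Cl)c3)[C@@H]2c2ccccc2)cc1` gives 16 10^-6 cm/s

In an ADME assay on MDCK-II cells (Canis lupus familiaris) for permeability (a higher number here means that the compound crosses the layer faster, a lower number that the compound crosses the layer more slowly), compound 2 stands highest of the two, with 16 10^-6 cm/s as its number, and compound 1 lies under it by more than the scatter. Compound 3 `O=C(O)c1ccc(CN2CCC[C@H](O[C@H](CO)c3cc(Cl)cc(Cl)c3)[C@@H]2c2ccccc2)c([N+](=O)[O-])c1` carries nitro in place of hydrogen on an aromatic carbon, so that 4-carboxyphenyl becomes 4-carboxy-2-nitrophenyl, and the full count of that change reads nitro in place of hydrogen on an aromatic carbon here. Among the measured compounds shown here, the only measured step is an 8.0-fold higher number from compound 1 to compound 2 (0.90 log units; beyond the scatter), modest in size. For the measured compounds named here, it replaced a whole group, 1H-imidazol-2-yl, so it is a weak guide, and no nitro compound has been measured yet. No step beyond the scatter is therefore expected in this assay for this change. The estimate amounts to a 1.2-fold lower number from compound 2 to compound 3 (0.09 log units; within the scatter) as the expected step. Compound 3 is expected at 13 10^-6 cm/s, with an estimated range from 5 10^-6 cm/s to 30 10^-6 cm/s.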

Compound 3, apparent permeability: 10 10^-6 cm/s
Compound 3: middle estimate off by 1.3-fold (0.11 log units), on the high side; low and high end bracket the measured number.
By their numbers in this assay, from the lowest: compound 1; then compounds 3 and 2 (each within the scatter of the next).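

In this assay the result is a 1.6-fold lower number from compound 2 to compound 3 (0.20 log units; within the scatter), so placing a nitro group, with its 3 heavy atoms, on this aromatic carbon, ortho to a large group and meta to a carboxy group, keeps the number within the usual scatter. The second step, a 5.0-fold higher number from compound 1 to compound 3 (0.70 log units; beyond the scatter), also lies beyond the scatter, so the gap to the 1H-imidazol-2-yl compound seen without the nitro group remains with it in place. No supporting measurement is available to explain this result.

As far as these compounds go, whether a different group on this same carbon, such as an amine or a single fluorine atom, would also stay within the scatter remains open. From the compounds shown here alone, the effect of a nitro group on any other carbon of this ring is equally open.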